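Small Step Expected at the Carbonyl Carbon

This account rests on a few compounds, and the source may have more. Where it says the series, first, only, none or still open, it means among the compounds named here.

Measured so far:
Compound 1 `COc1cc(/C=C/C(=O)c2cccc(NC(=O)c3ccc(Cl)cc3)c2)ccc1O`: 3.82 ug/mL
Compound 2 `COc1cc(/C=C/C(=O)c2cccc(NC(=O)C(C)C)c2)ccc1O`: 3.47 ug/mL

Within the data shown here, in a functional assay on Vero cells (Chlorocebus sabaeus) for inhibition (on this read-out lower numbers stand for stronger inhibition and higher numbers for weaker inhibition), compound 2 gives 3.47 ug/mL, and it cannot be told apart from compound 1, the only other measured compound. The step between them is a 1.1-fold lower number from compound 1 to compound 2 (0.04 log units; within the scatter).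

Compound 3 `COC(=O)C(=O)Nc1cccc(C(=O)/C=C/c2ccc(O)c(OC)c2)c1` keeps the core of compound 2 and changes one group: methoxycarbonyl in place of isopropyl on a carbonyl carbon. In words, methoxycarbonyl stands in place of isopropyl on a carbonyl carbon whose other neighbours are an amide-type nitrogen.

Among the measured compounds shown here, only one measured step bears on this change. It also replaced a group on a carbonyl carbon, with isopropyl in place of 4-chlorophenyl, and its size was a 1.1-fold lower number from compound 1 to compound 2 (0.04 log units; within the scatter). A single small step is thin evidence, and methoxycarbonyl itself has not been tested, so no direction can be favoured. The expectation in this assay is no step beyond the scatter.

The expected change is a 1.1-fold higher number from compound 2 to compound 3 (0.03 log units; within the scatter). Compound 3 is estimated at 3.7 ug/mL, with an expected range from 1.6 ug/mL to 8.5 ug/mL.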

Compound 3, half-maximal inhibitory concentration: 3.55 ug/mL
For compound 3 the middle estimate is 1.0-fold (0.02 log units) above the measured one; the range from low to high includes it.
By their numbers in this assay, from the lowest: compounds 2, 3 and 1 (each within the scatter of the next).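

In this assay, the group on this carbonyl carbon has now been varied three ways, and the three compounds cannot be told apart. Among these compounds, putting methoxycarbonyl in place of isopropyl leaves no step beyond the scatter (a 1.0-fold higher number from compound 2 to compound 3 (0.01 log units; within the scatter)), and neither does putting it in place of 4-chlorophenyl (a 1.1-fold lower number from compound 1 to compound 3 (0.03 log units; within the scatter)), so the earlier flat comparison now extends to a group with 2 hydrogen-bond acceptors, where isopropyl and 4-chlorophenyl were the only groups compared before. Nothing available here explains why these three groups read alike.

Still open, on these data alone, is whether this tolerance lasts with quite different groups on the same carbonyl carbon, such as an amine, a carboxylic acid or a longer chain like n-hexyl, since three compounds with no step beyond the scatter set no limit on what the position accepts. All three compounds also share the rest of the core, so they say nothing about how the other parts of that core bear on this read-out.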